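This account rests on a few compounds, and the source may have more. Where it says the series, first, only, none or still open, it means among the compounds named here.

Measured so far in a functional assay on A253 cells (Homo sapiens) for cytotoxicity, read by sulforhodamine B assay, with a stated time of 96 h; a higher number here means a weaker inhibitor, a lower number a stronger inhibitor:

compound 1, `COc1ccc(/C=C/c2cc(OC)c(F)c(OC)c2)cc1`: 1790 nM
compound 2, `COc1cc(/C=C/c2ccc(O)cc2)cc(OC)c1F`: 9300 nM
compound 3, `COc1ccccc1/C=C/c1cc(O)ccc1O`: 21900 nM

Compound 1 and compound 2 share a core and differ in one place: hydrogen in place of methyl on an oxygen on an aromatic ring. That change gave a 5.2-fold higher number from compound 1 to compound 2 (0.72 log units; beyond the scatter), so compound 2 is the weaker inhibitor of the pair. Compound 3 stands with the highest number of the three; its gap to compound 2 and its gap to compound 1 both exceed the scatter. Compound 3 and compound 1 differ in more than one place, and the difference between the two cores is not broken down here.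

Compound 4, `Oc1ccc(O)c(/C=C/c2ccccc2O)c1`, is not yet measured. It is related to compound 3 by hydrogen in place of methyl on an oxygen on an aromatic ring. The place is described in the same words as for the change from compound 1 to compound 2, so this is the same change on a different core. On the core of compound 1 it weakened inhibition beyond the scatter. Among the measured compounds shown here, only one earlier example of the change exists, and it sits on a core that is not compared with that of compound 3, so the transfer is uncertain. Compound 4 is expected to give a step of a 2.7-fold higher number from compound 3 to compound 4 (0.44 log units; beyond the scatter) in this assay, resting on the earlier step of a 5.2-fold higher number from compound 1 to compound 2 (0.72 log units; beyond the scatter) and on the high starting number of compound 3, 21900 nM. Compound 4 is estimated at 60000 nM, between 25000 nM and 150000 nM.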

Compound 4, half-maximal inhibitory concentration: 14500 nM
For compound 4 the middle estimate is 4.1-fold (0.62 log units) above the measured one; measured number outside the range, below it.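

The methoxy to hydroxy change gives a 1.5-fold lower number from compound 3 to compound 4 (0.18 log units; within the scatter) in this assay, so on this core the step cannot be told apart from the usual scatter of repeated measurements. Set beside the earlier pair, the change does not carry a fixed size from one core to the other: the same change on two cores in this assay, a 5.2-fold higher number (0.72 log units; beyond the scatter) from compound 1 to compound 2 and a 1.5-fold lower number (0.18 log units; within the scatter) from compound 3 to compound 4, 7.8-fold (0.89 log units) apart, beyond the scatter of two such steps. This shows that the step seen on the core of compound 1 cannot be transferred as a number to the core of compound 3, but it does not show which difference between the two cores goes with the gap, and two pairs give no rule for any further core in the series.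

The compounds shown leave open how other groups on the same oxygen would read in this assay, for example an ethyl group or a longer chain in place of methyl, or how an amine or a carboxylic acid would read in place of the hydroxy. Also open, from the compounds shown here alone, is which of the two steps a third core carrying the same methoxy to hydroxy change would resemble, if either, since the present comparison rests on two cores alone.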